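A few compounds are considered here, and "the series" means these few. Any claim that something is new, unique, unknown or untested is made for them only; others in the source may bear on it.

In a functional assay on Caco-2 cells (Homo sapiens) for inhibition, read by sulforhodamine B assay, with a stated time of 48 h (a higher number here means a weaker inhibitor, a lower number a stronger inhibitor), compound 3 `O=c1c([C@@H]2C[C@H](c3ccccc3)ON2c2ccccc2)coc2cc(Cl)c(Cl)cc12` gives 23500 nM and is the only one of the three measured compounds with an actual number. Compound 1 `COC(=O)[C@H]1C[C@@H](c2coc3ccccc3c2=O)N(c2ccccc2)O1` gives > 60000 nM as a limit of the assay and not a number. Compound 2 `CCO[C@H]1C[C@@H](c2coc3ccccc3c2=O)N(c2ccccc2)O1` gives > 60000 nM and this too is a limit. Between these two stands a step that the two limits leave unreadable from compound 1 to compound 2 and it offers no size to carry forward.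

Compound 4 `CCO[C@H]1C[C@@H](c2coc3cc(Cl)c(Cl)cc3c2=O)N(c2ccccc2)O1` keeps the core of compound 3 but has ethoxy in place of phenyl on a saturated ring carbon and has not yet been measured. Going by the values given here, no measured step covers this exchange, so the nearest guide is the limit of > 60000 nM in this assay, at which 2 of the 3 values shown sit, and not a step size. Compound 2 carries the same ethoxy on a core without chlorine and sits at the limit > 60000 nM so the expected direction in this assay is toward weaker inhibition. The expected change is a 2.1-fold higher number from compound 3 to compound 4 (0.33 log units; beyond the scatter) and it remains a rough expectation resting on very few compounds. For compound 4 the estimated value is 50000 nM with an expected range from 20000 nM to 120000 nM and the assay may well report only a limit.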

Compound 4, half-maximal inhibitory concentration: > 60000 nM
Compound 4 ended at the assay's limit; the forecaster's own chance of this, stated with the estimate: 50%; at least 1.2-fold (0.07 log units) between middle value and limit.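

In this assay, the exchange of phenyl for ethoxy on the saturated ring carbon next to the ring oxygen gives an at least 2.5-fold higher number from compound 3 to compound 4 (0.40 log units; beyond the scatter), the only step among the compounds shown whose size has a readable bound. The earlier pair carried methoxycarbonyl or ethoxy at this position on a core without chlorine and gave no readable step, whereas this change on the core of compound 3 shows that losing the phenyl group costs measurable inhibition. Compound 4 gives > 60000 nM, which is a limit of the assay and not a number, so the step has a lower bound but no upper one, and the only measured number still belongs to the compound with phenyl at this position: the limit of > 60000 nM in this assay, at which 3 of the 4 values shown sit.

From the compounds shown here alone, whether a benzyl group, a longer chain such as butoxy, or an amine at this position would keep a measurable number on this core remains open. Going by these compounds, it is equally open whether a phenyl ring bearing a fluorine or a methoxy group would give a lower number than compound 3 does.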